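Clearance across the amino-substituted series, compound 3 to compound 4

This account rests on a few compounds, and the source may have more. Where it says the series, first, only, none or still open, it means among the compounds named here.

Compound 3 `CN1CCN(c2ccc(Cn3c(=O)[nH]c4c(N)nc(C(F)(F)F)cc43)cn2)CC1` carries a 4-methylpiperazin-1-yl group on the shared core. In an in vitro ADME assay on microsomes from liver (Rattus norvegicus) for pharmacokinetics (on this read-out lower numbers stand for slow clearance and higher numbers for fast clearance), compound 3 gives 46 mL.min-1.g-1, the highest of the two numbers shown. Compound 2 `CN(C)CCN(C)c1ccc(Cn2c(=O)[nH]c3c(N)nc(C(F)(F)F)cc32)cn1` gives 11 mL.min-1.g-1 in this assay, and the step of a 4.2-fold higher number from compound 2 to compound 3 (0.62 log units; beyond the scatter) is modest and beyond the scatter. Compound 1 `Nc1nc(C(F)(F)F)cc2c1[nH]c(=O)n2Cc1ccc(NCCO)nc1` reaches only a limit of this assay, < 8.5 mL.min-1.g-1 (the limit of < 8.5 mL.min-1.g-1 in this assay, at which 1 of the 3 values shown sits). The step of an at least 5.4-fold higher number from compound 1 to compound 3 (0.73 log units; beyond the scatter) is at least modest, while the step of an at least 1.2-fold higher number from compound 1 to compound 2 (0.11 log units; that floor lies within the scatter) has a floor that lies within the scatter.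

Compound 4 `CN(C)CCNc1ccc(Cn2c(=O)[nH]c3c(N)nc(C(F)(F)F)cc32)cn1` is not yet measured. (2-(dimethylamino)ethyl)amino in place of 4-methylpiperazin-1-yl on an aromatic carbon This change largely reverses the step from compound 2 to compound 3, differing from it only by one methyl group on the amine nitrogen, so the step of a 4.2-fold higher number from compound 2 to compound 3 (0.62 log units; beyond the scatter) is the closest guide and a downward step of similar size is expected. Compound 4 is therefore estimated to give 13 mL.min-1.g-1 in this assay, with a range from 7 mL.min-1.g-1 to 30 mL.min-1.g-1. The expected step of a 3.5-fold lower number from compound 3 to compound 4 (0.55 log units; beyond the scatter) is thus modest and downward.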

Compound 4, intrinsic clearance in microsomes in the Rattus norvegicus assay: 16 mL.min-1.g-1
For compound 4 the middle estimate is 1.2-fold (0.09 log units) below the measured one, within the range that was stated.
By their numbers in the Rattus norvegicus assay, from the lowest: compounds 2 and 4 (each within the scatter of the next); then compound 3. At a limit, below all of these: compound 1.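

On the aromatic carbon next to the ring nitrogen, in the Rattus norvegicus assay, opening the ring of compound 3 to the open chain gives a 2.9-fold lower number from compound 3 to compound 4 (0.46 log units; beyond the scatter), while removing the methyl on the nitrogen gives a 1.5-fold higher number from compound 2 to compound 4 (0.16 log units; within the scatter), so among compounds 2, 3 and 4 the ring-bearing compound 3 stands apart and the two open chains cannot be told apart. In the Rattus norvegicus assay compound 1 remains a limit, so an at least 1.8-fold higher number from compound 1 to compound 4 (0.27 log units; that floor lies within the scatter) gives only a floor for exchanging hydroxy for dimethylamino: the limit of < 8.5 mL.min-1.g-1 in the Rattus norvegicus assay, at which 1 of the 4 values shown sits. In a physicochemical assay for solubility, measured as thermodynamic solubility (on this read-out lower numbers stand for lower solubility and higher numbers for higher solubility), compound 3 gives 317 ug/mL and compound 4 gives 483 ug/mL, and a 1.5-fold higher number from compound 3 to compound 4 (0.18 log units; within the scatter) shows that opening the ring leaves no readable difference in solubility.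

On these data alone, whether the ring itself or the second ring nitrogen goes with the faster clearance remains open; a morpholin-4-yl or piperidin-1-yl group would separate the two. A longer chain between the two amines is also untested among the compounds shown.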